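The source may hold more compounds than are shown below. What is called first, only, known or untested is meant among the compounds shown, and "the series" means these compounds.

Compound 1 `Cc1nn(-c2ncnc3nc[nH]c23)c2c1C(OC1CCCC1)CC(=O)N2`: 2 nM
Compound 2 `Cc1nn(-c2ncnc3nc[nH]c23)c2c1C(OCc1ccccc1Cl)CC(=O)N2`: 2 nM

In a functional assay on HEK293 cells for agonist activity at G-protein coupled receptor 39 (Homo sapiens), read by scintillation proximity assay and inositol phosphate accumulation, with a stated time of 75 min, in the presence of a further agent that is not named here (on this read-out lower numbers stand for an effect already at smaller amounts and higher numbers for an effect only at larger amounts of compound), compound 1 gives 2 nM and compound 2 gives 2 nM. The single step between the two, no change at the digits printed from compound 1 to compound 2 (within the scatter), came from putting 2-chlorobenzyl in place of cyclopentyl on the oxygen on a saturated carbon, so compound 2 stands level with compound 1 on the numbers shown. Compound 3 `Cc1nn(-c2ncnc3nc[nH]c23)c2c1C(OCc1ccccc1C#N)CC(=O)N2` keeps that benzyl group and differs from compound 2 by cyano in place of chloro on an aromatic carbon. Among the measured compounds shown here, no measured step alters this aromatic carbon itself; the only step available, no change at the digits printed from compound 1 to compound 2 (within the scatter), shows that a large change of the group on the oxygen left the read-out unchanged, which gives no reason to expect a smaller change on the same group to move it far. The step of a 1.5-fold higher number from compound 2 to compound 3 (0.18 log units; within the scatter) is therefore expected to stay within the scatter. Compound 3 is estimated at 3 nM, with a range from 1 nM to 10 nM.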

Compound 3, half-maximal effective concentration: 8 nM
For compound 3 the middle estimate is 2.7-fold (0.43 log units) below the measured one; the range from low to high includes it.
By their numbers in this assay, from the lowest: compounds 1 and 2 (each within the scatter of the next); then compound 3.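

In this assay the group on this aromatic carbon turns out to matter: cyano in place of chloro gives a 4.0-fold higher number from compound 2 to compound 3 (0.60 log units; beyond the scatter) and takes the read-out beyond the scatter, though only modestly. The comparison with the cyclopentyl compound points the same way, with a 4.0-fold higher number from compound 1 to compound 3 (0.60 log units; beyond the scatter) for 2-cyanobenzyl in place of cyclopentyl on the oxygen, so the level result for 2-chlorobenzyl does not hold for every benzyl group on that oxygen. Nothing available explains why this swap raises the number.

As far as these compounds go, it remains open how other groups on this same aromatic carbon would behave, for example fluoro, methyl or methoxy. Also open, from the compounds shown here alone, is whether a larger group there, such as an amine or a carboxylic acid, would raise the number further.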